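The source may hold more compounds than are shown below. What is called first, only, known or untested is meant among the compounds shown, and "the series" means these compounds.

Notes on the series, step from compound 2 to compound 3.

In a toxicity assay on Vero C1008 cells (Chlorocebus sabaeus) for cytotoxicity, read by neutral red uptake, with a stated time of 5 days (on this read-out higher numbers stand for lower toxicity in this test and lower numbers for higher toxicity in this test), compound 1 `CC(C)(C)c1ccc(N(C(=O)c2ccco2)C(C(=O)NC2CC2)c2cccnc2)cc1` gives 52800 nM. Among the compounds with values here, compound 2 `CC(C)(C)c1ccc(N(C(=O)c2ccco2)C(C(=O)NC2CCCC2)c2cccnc2)cc1` gives 101000 nM in this assay, the highest of the two numbers so far, though the step of a 1.9-fold higher number from compound 1 to compound 2 (0.28 log units; within the scatter) stays within the scatter, so no order between the two compounds is claimed. Compound 3 `CC(C)(C)c1ccc(N(C(=O)c2ccco2)C(C(=O)NC2CCCCC2)c2cccnc2)cc1` has not yet been measured in this assay. It differs from compound 2 as follows: cyclohexyl in place of cyclopentyl on an amide-type nitrogen. Within the data shown here, the only measured step that bears on this change is the one at the same amide-type nitrogen, a 1.9-fold higher number from compound 1 to compound 2 (0.28 log units; within the scatter), which ran in the direction of a higher number but did not leave the scatter. The same kind of change is therefore expected to give at most a modest shift, a 1.3-fold higher number from compound 2 to compound 3 (0.11 log units; within the scatter), and possibly none beyond the scatter. Compound 3 is estimated at 130000 nM in this assay, with a range from 50000 nM to 330000 nM.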

Compound 3, half-maximal cytotoxic concentration: 18200 nM
Compound 3: the middle estimate sits 7.1-fold (0.85 log units) above what was measured; the measured number lies below the stated range.
By their numbers in this assay, from the lowest: compound 3; then compounds 1 and 2 (each within the scatter of the next).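

In this assay, within the data shown here, the amide-type nitrogen turns out not to be indifferent to the ring it carries: cyclohexyl in place of cyclopentyl gives a 5.5-fold lower number from compound 2 to compound 3 (0.74 log units; beyond the scatter), the first step at this position to leave the scatter. Cyclohexyl in place of cyclopropyl gives a 2.9-fold lower number from compound 1 to compound 3 (0.46 log units; beyond the scatter), so compound 3 stands apart from both compound 1 and compound 2, which cannot be told apart from each other, and the number does not follow ring size in one steady direction across the three compounds. Nothing available explains why the change from the five-membered to the six-membered ring lowers the number.

As far as these compounds go, whether this lower number belongs to cyclohexyl alone or continues with larger groups stays open. A cycloheptyl ring or an open hexyl chain on the same nitrogen would separate ring size from carbon count.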